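Flipping one stereocentre on the weaker compound of the pair

This account rests on a few compounds, and the source may have more. Where it says the series, first, only, none or still open, it means among the compounds named here.

Within the data shown here, in a functional assay (B cell) with Homo sapiens as the target (a higher number here means a weaker inhibitor, a lower number a stronger inhibitor), only two compounds have values so far. Compound 1 (`Cc1nc2ccc(CN(C)c3ccc(C(=O)N[C@@H](C[C@@H](F)C(=O)O)C(=O)O)s3)cc2c(=O)[nH]1`) gives 8.08 nM and compound 2 (`Nc1nc2c(c(=O)[nH]1)C[C@@H](CCc1ccc(C(=O)N[C@@H](C[C@@H](F)C(=O)O)C(=O)O)cc1)CN2`) gives 2930 nM in the same read-out. Compound 2 therefore holds the higher number of the two and stands as the weaker inhibitor, with a gap well beyond the scatter.

The next compound is compound 3 (`Nc1nc2c(c(=O)[nH]1)C[C@@H](CCc1ccc(C(=O)N[C@@H](C[C@H](F)C(=O)O)C(=O)O)cc1)CN2`). Its change from compound 2 is purely one of configuration (the two compounds have the same atoms and bonds and differ only in configuration as drawn: 1 of 3 stereo elements differ; a stereocentre at a saturated chain carbon is drawn R in compound 2 and S in compound 3): a stereocentre at a saturated chain carbon is drawn R in compound 2 and S in compound 3.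

Among the measured compounds shown here, no measured pair shows what such a change does, so the size of the step remains poorly constrained. A lower number in this assay is nevertheless expected, beyond the scatter, since compound 2 at 2930 nM sits far above compound 1 at 8.08 nM and leaves much room downward. The expected change is (a 12-fold lower number from compound 2 to compound 3 (1.07 log units; beyond the scatter)). For compound 3 the estimated value is 250 nM with an expected range from 25 nM to 3000 nM in this assay.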

Compound 3, half-maximal inhibitory concentration: 2930 nM
Compound 3: middle estimate off by 12-fold (1.07 log units), on the low side, within the range that was stated.
By their numbers in this assay, from the lowest: compound 1; then compounds 2 and 3 (each within the scatter of the next).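

In this assay the drawn R or S configuration at this saturated chain carbon makes no visible difference on the core of compound 2, with no change at the digits printed from compound 2 to compound 3 (within the scatter). Among these compounds, this is the first reading of a configuration change, and the comparison is a clean one, since nothing else varies between the two structures: the fact that compounds 2 and 3 differ only in the configuration as drawn. For this one pair, then, the stereocentre at the saturated chain carbon can be drawn either way with no shift in the read-out, although a single pair sets no rule for the series, and the flat result says nothing about how the compounds act.

On these data alone, whether the same inversion would be as silent on compound 1, at 8.08 nM, stays open, as does the behaviour of the other two stereo elements of compound 2. Also open, as far as these compounds go, is what a chlorine atom or a hydroxyl group in place of the fluoro group would do in this assay, on either core.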